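Adding a carboxy group to compound 3

The source may report more compounds than this note shows. Statements on the series, on what has been measured and on what is new or still open speak of the compounds shown alone.

Compounds measured so far in an ADME assay on the whole organism (Rattus norvegicus) for pharmacokinetics, at a dose of 2 mg/kg by the oral route (a lower number here means that a smaller share of the oral dose reaches the circulation, a higher number that a larger share of the oral dose reaches the circulation), are these
- compound 1 `O=C(NCc1ccc(F)cc1)c1cnc(-c2ccccn2)nc1O` gives 67%
- compound 2 `CC(C)(NC(=O)c1cnc(-c2cscn2)nc1O)c1ccccc1` gives 61%
- compound 3 `CC(C)(NC(=O)c1cnc(-n2cccn2)nc1O)c1ccccc1` gives 99%

Compound 3 stands highest of the three, with compound 1 nearest and compound 2 furthest, both lower beyond the scatter. Compound 4 `CC(C)(NC(=O)c1cnc(-n2cc(C(=O)O)cn2)nc1O)c1ccccc1` differs from it by carboxy in place of hydrogen on an aromatic carbon in the change from 1H-pyrazol-1-yl to 4-carboxy-1H-pyrazol-1-yl. Among the compounds with values here, one measured step bears on this, and it is large: a number 38 percentage points higher from compound 2 to compound 3 (beyond the scatter) on exchanging 1,3-thiazol-4-yl for 1H-pyrazol-1-yl. Within the data shown here, no measured compound carries a carboxy, so the size stays uncertain. A fall is expected because compound 3 at 99% leaves almost no room upward. The expected change is a number 39 percentage points lower from compound 3 to compound 4 (beyond the scatter) and should be large. In this assay compound 4 is estimated at 60% (range 25% to 95%).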

Compound 4, oral bioavailability: 3%
Estimate against measurement, compound 4: 57 percentage points above; measured number below the stated range.
By their numbers in this assay, from the lowest: compound 4; then compounds 2 and 1 (each within the scatter of the next); then compound 3.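

In this assay, within the data shown here, carboxy in place of hydrogen on the 1H-pyrazol-1-yl group brings a number 96 percentage points lower from compound 3 to compound 4 (beyond the scatter) and so shows that this aromatic carbon, unchanged in the earlier compounds, can carry a change that leaves almost none of the oral dose in the circulation. The 4-carboxy-1H-pyrazol-1-yl group also falls short of 1,3-thiazol-4-yl, with a number 58 percentage points lower from compound 2 to compound 4 (beyond the scatter) and thus a reversal of the order seen with the unsubstituted group. Nothing shown accounts for this loss.

Among these compounds, only one group is seen at this carbon, so it stays open whether a methyl ester, a primary carboxamide or an aminomethyl group there would keep the number close to that of compound 3.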